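A change on the carbonyl carbon of compound 2

The source may hold more compounds than are shown below. What is called first, only, known or untested is meant among the compounds shown, and "the series" means these compounds.

Two measured compounds, compound 1 `COc1ccc(-c2cc(/C=C/C(=O)c3ccc(N)cc3)[nH]n2)cc1` and compound 2 `COc1cc(-c2cc(/C=C/C(=O)c3ccc(Cl)c(Cl)c3)[nH]n2)cc(OC)c1OC`, have been tested in a functional assay on ACHN cells (Homo sapiens) for cytotoxicity, read by sulforhodamine B assay, with a stated time of 48 h, tested at 100 uM; on this read-out higher numbers stand for a weaker effect at the one concentration tested and lower numbers for a stronger effect. In this assay compound 1 gives -73%, while compound 2 gives 16%. Compound 2 therefore stands at the highest, and thus weakest, of the two numbers; its nearest neighbour, compound 1, lies far lower, a gap well beyond the scatter. Among the measured compounds shown here, no pair among the measured compounds differs in only one place, so no single step has been computed.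

Compound 3 `COc1ccc(C(=O)/C=C/c2cc(-c3cc(OC)c(OC)c(OC)c3)n[nH]2)cc1` has not yet been measured in this assay. Compared with compound 2, it carries 4-methoxyphenyl in place of 3,4-dichlorophenyl on a carbonyl carbon. Because compound 2 gives 16% and compound 1, with a different group on the carbonyl carbon, gives -73%, a move towards a stronger effect seems possible, but the two measured compounds also differ elsewhere, so the guide is weak. The step from compound 2 to compound 3 is expected to be a moderate decrease, a number 36 percentage points lower from compound 2 to compound 3 (beyond the scatter), probably beyond the scatter. On that basis compound 3 is estimated at -20%, with a range from -70% to 30%.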

Compound 3, a percentage reported as activity, at one concentration (the size of the read-out at that concentration, not a potency): -93%
Compound 3: middle estimate off by 73 percentage points, on the high side, and the stated range ends above it.
By their numbers in this assay, from the lowest: compound 3; then compound 1; then compound 2.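

Among the compounds shown here, with the rest of the molecule unchanged, 4-methoxyphenyl in place of 3,4-dichlorophenyl on a carbonyl carbon gives a number 109 percentage points lower from compound 2 to compound 3 (beyond the scatter) in this assay and is the first change here that can be read in isolation. The earlier pair differed in more than one place, whereas this step shows that the group on this carbonyl carbon can by itself shift the read-out strongly towards a stronger effect. The two groups match in heavy-atom count and each holds one six-membered aromatic ring of carbon only, so the step sets two chlorine atoms against a methoxy oxygen, but nothing shown accounts for the size of the shift.

The compounds shown leave open whether the stronger effect follows from the arrival of the methoxy group or from the departure of the chlorine atoms, a question that an unsubstituted phenyl or a 4-hydroxyphenyl on the same carbonyl carbon would help to settle. As far as these compounds go, it also remains open whether the same exchange would carry over to the core of compound 1, or whether it would hold at concentrations other than the single one tested.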